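Nitro in Place of Fluoro: An Expected Step

The source may report more compounds than this note shows. Statements on the series, on what has been measured and on what is new or still open speak of the compounds shown alone.

Of the compounds shown here, three sharing one core have been tested in a functional assay on SW-620 cells (Homo sapiens) for antiproliferative activity, read by MTT assay, with a stated time of 24 h; on this read-out lower numbers stand for stronger inhibition and higher numbers for weaker inhibition. Compound 1 `COc1cc(OC)c(OC)cc1/C=C/C(=O)c1ccc(OC)c2c1OC(C)(C)C=C2` gives > 10000 nM, which is a limit of the assay and not a number. Compound 2 `COc1ccc(C(=O)/C=C/c2cccc(F)c2)c2c1C=CC(C)(C)O2` likewise gives > 10000 nM in this assay, again a limit rather than a number. Compound 3 `COc1ccc(C(=O)/C=C/c2ccc(-c3ccccc3)cc2)c2c1C=CC(C)(C)O2` also reaches only > 10000 nM in this assay, a limit once more. No two of these compounds differ in a single place, so no measured step can be drawn between them; what the numbers show is the limit of > 10000 nM in this assay, at which 3 of the 3 values shown sit, meaning none of the three reached a measurable value.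

Compound 2 therefore stands at the limit together with the other two, with no number of its own to place it higher or lower.

Compound 4 `COc1ccc(C(=O)/C=C/c2cccc([N+](=O)[O-])c2)c2c1C=CC(C)(C)O2` is not yet measured. It differs from compound 2 in one spot: nitro in place of fluoro on an aromatic carbon. Among the compounds with values here, since every measured value sits at the limit, there is no step of known size from which to read how far such a change might move the number. The step that the estimate means is a step that the limit leaves unreadable from compound 2 to compound 4, expected to be nothing beyond the scatter. Compound 4 is expected at 15000 nM, with a range from 5000 nM to 50000 nM, and most likely it will again be reported only as a limit.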

Compound 4, half-maximal inhibitory concentration: 4090 nM
Estimate against measurement, compound 4: 3.7-fold (0.56 log units) above; the measured number lies below the stated range.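

Swapping 3-fluorophenyl for 3-nitrophenyl yields the only actual number in this set: in this assay compound 4 gives 4090 nM. With nitro in place of fluoro on this aromatic carbon, meta to a large group, the data show an at least 2.4-fold lower number from compound 2 to compound 4 (0.38 log units; beyond the scatter), so the group at this place can move the read-out by more than the usual scatter, something that values sitting only at a limit could not show. Going by these compounds, that step marks a minimum rather than a measured size, because compound 2 gives > 10000 nM, which is a limit of the assay and not a number, so the true distance on the weak side remains unknown: the limit of > 10000 nM in this assay, at which 3 of the 4 values shown sit.

The compounds shown leave open whether nitro itself matters or whether other groups at this place, such as an amine, a carboxylic acid or a methoxy group, would give a measurable number too. They also leave open whether nitro would bring a similar change on another carbon of the same ring, and why this single change has the effect it has.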